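From Dimethyl Triazole to Dimethyl Imidazole on the Side Chain

A few compounds are considered here, and "the series" means these few. Any claim that something is new, unique, unknown or untested is made for them only; others in the source may bear on it.

In a functional assay on HUVEC cells (Homo sapiens), read by scintillation counting and thymidine incorporation, with a stated time of 24 h (on this read-out higher numbers stand for weaker inhibition and lower numbers for stronger inhibition), compound 1 (`CCC(C)n1ncn(-c2ccc(N3CCN(c4ccc(OC[C@@H]5CO[C@@](CC)(c6ccc(Cl)cc6Cl)O5)cc4)CC3)cc2)c1=O`) gives 353 nM and compound 2 (`CCC(C)n1ncn(-c2ccc(N3CCN(c4ccc(OC[C@@H]5CO[C@@](CC6CCCC6)(c6ccc(Cl)cc6Cl)O5)cc4)CC3)cc2)c1=O`) gives 512 nM while compound 3 (`CCC(C)n1ncn(-c2ccc(N3CCN(c4ccc(OC[C@@H]5CO[C@@](Cn6nc(C)nc6C)(c6ccc(Cl)cc6Cl)O5)cc4)CC3)cc2)c1=O`) gives 221 nM as its reading. Two steps fix where that last value stands, namely a 1.6-fold lower number from compound 1 to compound 3 (0.20 log units; within the scatter) on one side and a 2.3-fold lower number from compound 2 to compound 3 (0.36 log units; beyond the scatter) on the other. Compound 4 (`CCC(C)n1ncn(-c2ccc(N3CCN(c4ccc(OC[C@@H]5CO[C@@](Cn6cc(C)nc6C)(c6ccc(Cl)cc6Cl)O5)cc4)CC3)cc2)c1=O`) differs by 2,4-dimethyl-1H-imidazol-1-yl in place of 3,5-dimethyl-1H-1,2,4-triazol-1-yl on a saturated chain carbon bound to a saturated ring carbon in one place, with 2,4-dimethyl-1H-imidazol-1-yl in place of 3,5-dimethyl-1H-1,2,4-triazol-1-yl on a saturated chain carbon bound to a saturated ring carbon. Going by the values given here, no measured step makes this exchange, but changes at that place stayed modest, with a 1.5-fold higher number from compound 1 to compound 2 (0.16 log units; within the scatter) as the third example, so no step beyond the scatter is expected. The estimated change is a 1.1-fold higher number from compound 3 to compound 4 (0.05 log units; within the scatter) in size. Compound 4 is expected near 250 nM with an estimated range from 110 nM to 560 nM in this read-out.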

Compound 4, half-maximal inhibitory concentration: 492 nM
Compound 4: the middle estimate sits 2.0-fold (0.29 log units) below what was measured, within the range that was stated.
By their numbers in this assay, from the lowest: compounds 3, 1, 4 and 2 (each within the scatter of the next, the first and the last beyond it).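

In this assay, this position separates two aromatic rings with the same number of heavy atoms: 2,4-dimethyl-1H-imidazol-1-yl in place of 3,5-dimethyl-1H-1,2,4-triazol-1-yl gives a 2.2-fold higher number from compound 3 to compound 4 (0.35 log units; beyond the scatter). Compound 4 stays within the scatter of the methyl and cyclopentyl compounds, with a 1.0-fold lower number from compound 2 to compound 4 (0.02 log units; within the scatter) and a 1.4-fold higher number from compound 1 to compound 4 (0.14 log units; within the scatter), so an aromatic ring at this place does not by itself set a compound apart from them. No evidence is available on why the two rings differ. Going by these compounds, whether an unsubstituted imidazol-1-yl, a tetrazol-1-yl or a simple amine here would read like compound 3 or compound 4 remains open.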